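The compounds below may be only part of what the source reports. "The series", "measured", "known", "first", "only" and "open" are said of these compounds alone.

In a functional assay on HeLa cells (Homo sapiens) for inhibition, read by sulforhodamine B assay (a higher number here means a weaker inhibitor, a lower number a stronger inhibitor), compound 2, `CCOc1ccccc1NC1=CC(=O)c2c(nc3n2[C@H]2OC[C@@H](O)[C@H]2OC3)C1=O`, gives 8300 nM. Among the two values shown this is the only one that is a number; the other is a limit. Compound 1, `O=C1C(NC2CC2)=CC(=O)c2c1nc1n2[C@H]2OC[C@@H](O)[C@H]2OC1`, reaches only the limit of the assay at > 16000 nM in this assay. For the measured compounds named here, the single measured step, an at least 1.9-fold lower number from compound 1 to compound 2 (0.28 log units; that floor lies within the scatter), is accordingly a floor rather than a measured size, which the limit of > 16000 nM in this assay, at which 1 of the 2 values shown sits, makes plain. Compound 3, `O=C1C(NC2CCCCC2)=CC(=O)c2c1nc1n2[C@H]2OC[C@@H](O)[C@H]2OC1`, has not yet been measured in this assay; it differs from compound 2 as follows: cyclohexyl in place of 2-ethoxyphenyl on an amine nitrogen. Going by the values given here, no measured step covers an exchange of 2-ethoxyphenyl for cyclohexyl on this amine nitrogen, and the one step available, from cyclopropyl to 2-ethoxyphenyl on the same nitrogen, is a floor that lies within the scatter. He therefore expects for compound 3 a step of a 1.4-fold higher number from compound 2 to compound 3 (0.16 log units; within the scatter) in this assay, a small loss that may well stay within the scatter and might end at the limit. Compound 3 is estimated in this assay at 12000 nM, within 5000 nM to 30000 nM.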

Compound 3, half-maximal inhibitory concentration: > 16000 nM
Compound 3: only a limit was reported; the forecaster's own chance of this, stated with the estimate: 35%; middle value at least 1.3-fold (0.12 log units) away from the limit.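

The value of compound 3 in this assay is a limit of the assay and not a number. Cyclohexyl in place of 2-ethoxyphenyl on the amine nitrogen gives an at least 1.9-fold higher number from compound 2 to compound 3 (0.28 log units; that floor lies within the scatter), so a second non-aromatic carbon ring joins cyclopropyl without yielding a number, and compound 2 remains the only compound here with one, although this floor does not separate the two groups beyond the scatter. Compound 1 and compound 3 both rest at the limit, so the step between them cannot be read, and the size of the ring on this nitrogen can be given no effect: the limit of > 16000 nM in this assay, at which 2 of the 3 values shown sit.

The compounds shown leave open whether the number of compound 2 depends on the aromatic ring itself or on the ethoxy group it carries, a question that a plain phenyl, or a phenyl bearing a methoxy group or a carboxylic acid, would bear on. They also leave open how far compound 1 and compound 3 lie past the limit, and with it the true size of both steps to compound 2.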